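The compounds below may be only part of what the source reports. "The series", "measured", "known", "first", "only" and "open" are said of these compounds alone.

In a functional assay on NIH3T3 cells (Mus musculus) (on this read-out lower numbers stand for an effect already at smaller amounts and higher numbers for an effect only at larger amounts of compound), three compounds sharing one core have been measured: compound 1 (`Cn1cncc1C(OCc1ccc(C#N)cc1-c1ccc(F)c(Cl)c1)c1ccc(C#N)nc1`) gives 46 nM in this test, compound 2 (`Cn1cncc1C(OCc1ccc(C#N)cc1-c1cccc2ccccc12)c1ccc(C#N)nc1`) gives 46 nM and compound 3 (`Cn1cncc1C(OCc1ccc(C#N)cc1-c1cc(F)cc(F)c1)c1ccc(C#N)nc1`) gives 25 nM under the same conditions. Compound 3 does not stand apart from the other two, as its steps to both lie within the scatter. Compound 4 (`Cn1cncc1C(OCc1ccc(C#N)cc1-c1cc(Cl)cc(Cl)c1)c1ccc(C#N)nc1`) carries 3,5-dichlorophenyl in place of 3,5-difluorophenyl on an aromatic carbon, ortho to a large group and meta to a cyano group (3,5-dichlorophenyl in place of 3,5-difluorophenyl on an aromatic carbon). Three measured steps exchange the aromatic group at this same place: a 1.8-fold lower number from compound 1 to compound 3 (0.26 log units; within the scatter) and a 1.8-fold lower number from compound 2 to compound 3 (0.26 log units; within the scatter) and also no change at the digits printed from compound 1 to compound 2 (within the scatter) all stay within the scatter. None of these steps is the exact exchange made here, but together they give no reason to expect a large shift in this assay. The expected step, a 1.4-fold higher number from compound 3 to compound 4 (0.15 log units; within the scatter) as estimated, therefore stays within the scatter, with no firm direction. For compound 4 the estimated value is 35 nM with an expected range from 14 nM to 90 nM in this read-out.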

Compound 4, half-maximal effective concentration: 3.5 nM
Estimate against measurement, compound 4: 10-fold (1.00 log units) above; the whole stated range lies above it.
By their numbers in this assay, from the lowest: compound 4; then compounds 3, 1 and 2 (each within the scatter of the next).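

In this assay, the aromatic group at this place, ortho to a large group and meta to a cyano group, proves able to move the number well beyond the scatter: exchanging 3,5-difluorophenyl for 3,5-dichlorophenyl gives a 7.1-fold lower number from compound 3 to compound 4 (0.85 log units; beyond the scatter). The 3,5-dichlorophenyl group also stands clear of the other two groups, with a 13-fold lower number from compound 2 to compound 4 (1.12 log units; beyond the scatter) and a 13-fold lower number from compound 1 to compound 4 (1.12 log units; beyond the scatter), although those earlier groups had stayed within the scatter of one another. Compound 1 also carries chlorine in its 3-chloro-4-fluorophenyl group and goes against any reading that chlorine alone is enough among these compounds.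

Nothing shown here accounts for this shift. Going by these compounds, whether 3,5-dibromophenyl or 3,5-dimethylphenyl at this place would give a number like that of compound 4 remains open.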